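Losing the oxirane side chain in a growth-inhibition series

A few compounds are considered here, and "the series" means these few. Any claim that something is new, unique, unknown or untested is made for them only; others in the source may bear on it.

Compound 1 `CSc1ccc(C2=C(c3ccc(F)c(F)c3)C(=O)N3CCCC3C2)cc1`: 15000 nM
Compound 2 `CSc1ccc(C2=C(c3ccc(OCC4CO4)cc3)C(=O)N3CCCC3C2)cc1`: 80 nM

Going by the values given here, only two compounds have been measured so far, and they differ in more than one place, so no single change can be read from them. In a functional assay on U-251 cells (Homo sapiens) for cytotoxicity (on this read-out higher numbers stand for weaker inhibition of growth and lower numbers for stronger inhibition of growth), compound 2 gives 80 nM. This is the lower of the two numbers and lies beyond the scatter from compound 1.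

Compound 3 `CSc1ccc(C2=C(c3ccc(F)cc3)C(=O)N3CCCC3C2)cc1` has not yet been measured. Compared with compound 2, it carries fluoro in place of (oxiran-2-yl)methoxy on an aromatic carbon, para to a large group: fluoro in place of (oxiran-2-yl)methoxy on an aromatic carbon.

The closest guide is compound 1, which also has fluoro there and gives 15000 nM, although it is not identical to compound 3. A large rise is therefore expected, towards weaker inhibition of growth, with an estimated 130-fold higher number from compound 2 to compound 3 (2.10 log units; beyond the scatter). Compound 3 is expected at about 10000 nM, with an estimated range of 3000 nM to 30000 nM.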

Compound 3, concentration for 50% growth inhibition: 90 nM
Compound 3: the middle estimate sits 110-fold (2.05 log units) above what was measured, outside the stated range (below it).
By their numbers in this assay, from the lowest: compounds 2 and 3 (each within the scatter of the next); then compound 1.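

In this assay, putting fluoro in place of (oxiran-2-yl)methoxy on the aromatic carbon para to a large group gives a 1.1-fold higher number from compound 2 to compound 3 (0.05 log units; within the scatter) and shows that, in this pair, strong inhibition of growth does not depend on the side chain with its three-membered ring. The large gap lies elsewhere on that ring: at one further aromatic carbon, hydrogen in place of fluoro gives a 170-fold lower number from compound 1 to compound 3 (2.22 log units; beyond the scatter) and shows that this single atom separates the two fluoro compounds. Nothing measured here explains either result.

As far as these compounds go, whether an amine, a carboxylic acid or a longer chain at the para carbon would keep the number of compound 3 remains open. So does whether the second fluoro would have the same large effect with (oxiran-2-yl)methoxy in place of the first.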